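The compounds below may be only part of what the source reports. "The series", "measured", "known", "first", "only" and "open" are said of these compounds alone.

Measured so far:
- compound 1, `COc1ccc(Cn2c(CCc3ccccc3)nnc2[C@H](NC(=O)C(C)(C)N)c2c[nH]c3ccccc23)c(OC)c1`, giving 60 nM in an in vitro assay on LLC-PK1 cells for displacement of a labelled ligand from growth hormone secretagogue receptor type 1 (Homo sapiens); a lower number here means a stronger inhibitor, a higher number a weaker inhibitor
- compound 2, `COc1ccc(Cn2c(CCc3ccccc3)nnc2[C@H](NC(=O)c2ccncc2)c2c[nH]c3ccccc23)c(OC)c1`, giving 58 nM in this assay

Among the compounds with values here, compound 2 gives the lowest of the two numbers measured so far, but its nearest neighbour is compound 1, and the step of a 1.0-fold lower number from compound 1 to compound 2 (0.01 log units; within the scatter) lies within the scatter, so the two compounds cannot be told apart on this evidence.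

Compound 3, `COc1ccc(Cn2c(CCc3ccccc3)nnc2[C@H](NC(=O)c2ccccc2)c2c[nH]c3ccccc23)c(OC)c1`, differs from compound 2 at the carbonyl carbon of the amide: phenyl in place of pyridin-4-yl on a carbonyl carbon. Within the data shown here, the only measured step that bears on this position is a 1.0-fold lower number from compound 1 to compound 2 (0.01 log units; within the scatter), which swapped a small aliphatic group bearing a free amino group for the pyridin-4-yl ring without any change beyond the scatter. That step suggests this position tolerates rather different groups, though it is a single comparison and does not test the loss of the ring nitrogen directly.

On that basis no step beyond the scatter is expected from compound 2 to compound 3, that is a 1.0-fold higher number from compound 2 to compound 3 (0.01 log units; within the scatter), and compound 3 is estimated at 60 nM in this assay, with a range from 25 nM to 150 nM.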

Compound 3, half-maximal inhibitory concentration: 11.8 nM
Compound 3: the middle estimate sits 5.1-fold (0.71 log units) above what was measured; the measured number lies below the stated range.
By their numbers in this assay, from the lowest: compound 3; then compounds 2 and 1 (each within the scatter of the next).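

In this assay, the group on the carbonyl carbon of the amide turns out to matter: phenyl in place of pyridin-4-yl gives a 4.9-fold lower number from compound 2 to compound 3 (0.69 log units; beyond the scatter), although the two rings have the same number of heavy atoms and differ only in that one ring nitrogen becomes carbon. Phenyl in place of 1-amino-1-methylethyl gives a 5.1-fold lower number from compound 1 to compound 3 (0.71 log units; beyond the scatter), so the match between compound 1 and compound 2 did not mean that every group serves equally well at this place. Nothing measured here explains why the benzamide compound 3 gives the lower number, so the change can only be described, not accounted for.

The compounds shown leave open whether any ring nitrogen costs the same here, as pyridin-3-yl or pyridin-2-yl would show, or whether the step belongs to pyridin-4-yl alone. They also leave open whether the number would fall further or rise with a phenyl ring carrying a chlorine or methoxy group, or with a saturated ring such as cyclohexyl.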